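A few compounds are considered here, and "the series" means these few. Any claim that something is new, unique, unknown or untested is made for them only; others in the source may bear on it.

In a functional assay on the whole organism with Rattus norvegicus as the target (a higher number here means that more compound is needed for the effect, a lower number that less compound is needed), compound 1 (`Oc1nc(-c2ccccc2)ncc1-c1nn[nH]n1`) gives 100 mg/kg. Compound 2 (`C=CCOc1ccccc1-c1ncc(-c2nn[nH]n2)c(O)n1`), with allyloxy in place of hydrogen on an aromatic carbon, gives 0.24 mg/kg, a large change that amounts to a 420-fold lower number from compound 1 to compound 2 (2.62 log units; beyond the scatter). Compound 3 (`CCCOc1ccc(OC)cc1-c1ncc(-c2nn[nH]n2)c(O)n1`) gives 0.03 mg/kg, the lowest of the three numbers, so it needs the least compound for the effect.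

Compound 4 (`CCCOc1ccc(N)cc1-c1ncc(-c2nn[nH]n2)c(O)n1`) differs from compound 3 in one place: amino in place of methoxy on an aromatic carbon, para to a propoxy group. For the measured compounds named here, the only measured step between two compounds differing in one place, a 420-fold lower number from compound 1 to compound 2 (2.62 log units; beyond the scatter), replaces hydrogen with allyloxy. Going by the values given here, it bears only loosely on this change, since no measured pair swaps methoxy for amino, and it gives no direction here. The best guide is therefore the value of compound 3 itself, 0.03 mg/kg. In this assay no step beyond the scatter is expected, and the estimate is a 1.7-fold higher number from compound 3 to compound 4 (0.22 log units; within the scatter). The estimate for compound 4 is 0.05 mg/kg, with an expected range from 0.01 mg/kg to 0.3 mg/kg.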

Compound 4, dose for 50% inhibition: 0.1 mg/kg
For compound 4 the middle estimate is 2.0-fold (0.30 log units) below the measured one, within the range that was stated.
By their numbers in this assay, from the lowest: compound 3; then compound 4; then compound 2; then compound 1.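

Exchanging methoxy for amino on this aromatic carbon, para to a propoxy group, gives a 3.3-fold higher number from compound 3 to compound 4 (0.52 log units; beyond the scatter) in this assay and so shows that the group here affects the dose needed, even in a change this small. Of the two groups, methoxy needs less compound, although the modest size of the step shows that amino is tolerated at this position. Nothing measured on these compounds speaks to why the number moved.

Going by these compounds, two groups at one position cannot establish a trend, so it remains open how a hydroxy group, a chlorine atom or a carboxylic acid would behave there. On these data alone, it is also open whether a longer chain in place of the propoxy group would change the effect of the amino group.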